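The compounds below may be only part of what the source reports. "The series", "measured", "known", "first", "only" and "open" are said of these compounds alone.

Compound 1 `COc1ccc([C@@H]2CC(=O)c3c(O)cc(OCc4cn(Cc5cccc(C(F)(F)F)c5)nn4)cc3O2)cc1O`: 19900 nM
Compound 2 `COc1ccc([C@@H]2CC(=O)c3c(O)cc(OCc4cn(Cc5ccc(F)cc5)nn4)cc3O2)cc1O`: 15100 nM
Compound 3 `C=CCn1cc(COc2cc(O)c3c(c2)O[C@H](c2ccc(OC)c(O)c2)CC3=O)nn1`: 13800 nM

All three compounds share one core and differ only in the group carried on the saturated chain carbon bound to the aromatic nitrogen of the triazole. In a functional assay on RAW264.7 cells (Mus musculus) for inhibition, read by Griess assay, with stated times of 2 h and 24 h (on this read-out higher numbers stand for weaker inhibition and lower numbers for stronger inhibition), compound 1 gives 19900 nM, compound 2 gives 15100 nM and compound 3 gives 13800 nM. The steps of a 1.4-fold lower number from compound 1 to compound 3 (0.16 log units; within the scatter) and a 1.1-fold lower number from compound 2 to compound 3 (0.04 log units; within the scatter) leave compound 3 alongside the other two rather than apart from them, and the step of a 1.3-fold lower number from compound 1 to compound 2 (0.12 log units; within the scatter) is of the same kind. Exchanging a 3-(trifluoromethyl)phenyl for a 4-fluorophenyl or for a vinyl at this position has thus not moved the read-out beyond the scatter.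

For the measured compounds named here, compound 4 `COc1ccc([C@@H]2CC(=O)c3c(O)cc(OCc4cn(C5CCCCC5)nn4)cc3O2)cc1O` is the next member of this set. cyclohexyl in place of allyl on an aromatic nitrogen This change sits at the same position as the three measured steps, but it is the first that replaces a chain with a ring and the first without a double bond outside aromatic rings. Since every measured step at this position stayed within the scatter, the expectation for compound 4 in this assay is a step of a 1.0-fold higher number from compound 3 to compound 4 (0.01 log units; within the scatter), with no movement beyond the scatter in either direction. Compound 4 is therefore estimated at 14000 nM, within a range from 7000 nM to 28000 nM.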

Compound 4, half-maximal inhibitory concentration: 15600 nM
For compound 4 the middle estimate is 1.1-fold (0.05 log units) below the measured one, within the range that was stated.
By their numbers in this assay, from the lowest: compounds 3, 2, 4 and 1 (each within the scatter of the next).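

In this assay, placing a cyclohexyl, a six-membered non-aromatic ring of carbon only, on the aromatic nitrogen in place of the allyl gives a 1.1-fold higher number from compound 3 to compound 4 (0.05 log units; within the scatter), so neither the new ring nor the loss of the double bond outside aromatic rings separates the two compounds. The comparisons with the two benzyl groups give a 1.0-fold higher number from compound 2 to compound 4 (0.01 log units; within the scatter) and a 1.3-fold lower number from compound 1 to compound 4 (0.11 log units; within the scatter), which shows that a ring carried directly on this nitrogen stands level with rings that reach it through a saturated chain carbon. Across allyl, 4-fluorobenzyl, 3-(trifluoromethyl)benzyl and cyclohexyl, no step leaves the scatter, and nothing in the data shown offers an explanation for this flat result.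

The compounds shown leave open whether an amine or a carboxylic acid on this aromatic nitrogen would produce a step beyond the scatter. They also leave open whether any change elsewhere on the shared core, such as to its methoxy group or its hydroxyl groups, would move the number in this assay.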